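The source may report more compounds than this note shows. Statements on the series, on what has been measured and on what is new or still open speak of the compounds shown alone.

Measured in a functional assay on HUVEC cells (Homo sapiens) for inhibition; a higher number here means a weaker inhibitor, a lower number a stronger inhibitor:
- compound 1 `CN(c1ccc(NS(=O)(=O)Cc2ccccc2)cc1)c1ccnc(Nc2cccc(CS(C)(=O)=O)c2)n1`: 350 nM
- compound 2 `CN(c1ccc(NC(=O)Nc2ccc(OC(F)(F)F)cc2)cc1)c1ccnc(Nc2cccc(S(N)(=O)=O)c2)n1`: 5 nM
- compound 3 `CN(c1ccc(NC(=O)Nc2ccc(OC(F)(F)F)cc2)cc1)c1ccnc(Nc2ccc(S(N)(=O)=O)cc2)n1`: 37 nM

Compound 1 has the highest number of the three, and the gaps to both others lie beyond the scatter. Compound 4 `CN(c1ccc(NC(=O)NC2CCCC2)cc1)c1ccnc(Nc2cccc(CS(C)(=O)=O)c2)n1` is still unmeasured. It differs from compound 1 by cyclopentylcarbamoyl in place of benzylsulfonyl on a nitrogen on an aromatic ring.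

For the measured compounds named here, no measured step covers this change. The only one, a 7.4-fold higher number from compound 2 to compound 3 (0.87 log units; beyond the scatter), concerns 4-sulfamoylphenyl in place of 3-sulfamoylphenyl, so it offers only a sense of how large a single change can be here. More relevant, though indirect, are the carbamoyl-bearing compound 2 at 5 nM and compound 3 at 37 nM. Both also differ from compound 4 elsewhere, and neither carries cyclopentyl, so a modest shift towards a lower number in this assay is expected. The estimated step is a 5.0-fold lower number from compound 1 to compound 4 (0.70 log units; beyond the scatter). For compound 4 the expected value is 70 nM, with an estimated range of 12 nM to 350 nM.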

Compound 4, half-maximal inhibitory concentration: 1 nM
The estimate for compound 4 lay 70-fold (1.85 log units) above the measured number; the measured number lies below the stated range.
By their numbers in this assay, from the lowest: compound 4; then compound 2; then compound 3; then compound 1.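

Cyclopentylcarbamoyl in place of benzylsulfonyl on a nitrogen on an aromatic ring gives, in this assay, a 350-fold lower number from compound 1 to compound 4 (2.54 log units; beyond the scatter), which shows that this position can move the read-out strongly and by more than the only other single-place step, a 7.4-fold higher number from compound 2 to compound 3 (0.87 log units; beyond the scatter). The change is bundled: a six-membered aromatic ring of carbon leaves, a five-membered non-aromatic ring of carbon enters, and sulfonyl gives way to carbamoyl, with hydrogen-bond donors going from 0 to 1, so the step cannot be assigned to any one of these features. No measurement at hand bears on why the step is this large.

Still open, from the compounds shown here alone, is whether the ring or the linking group carries the step, which a benzyl group on the carbamoyl or a cyclopentyl group on the sulfonyl would separate. Also open, going by these compounds, is how the carbamoyl tolerates an open alkyl chain or a terminal amine in place of cyclopentyl.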